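Aryl change from compound 2 to compound 3

The compounds below may be only part of what the source reports. "The series", "measured", "known", "first", "only" and "open" are said of these compounds alone.

- compound 1 `O=C1Nc2ccc(F)cc2/C1=C/c1ccc(-c2cn(-c3cccc(F)c3)nn2)cc1`: 8190 nM
- compound 2 `N#Cc1cccc(-n2cc(-c3ccc(/C=C4\C(=O)Nc5ccc(F)cc54)cc3)nn2)c1`: > 20000 nM (a limit)

All values come from a functional assay on MKN-45 cells (Homo sapiens) for inhibition, read by CCK-8 assay, with a stated time of 24 h; on this read-out lower numbers stand for stronger inhibition and higher numbers for weaker inhibition. Compound 2 gives no number, only a limit: the limit of > 20000 nM in this assay, at which 1 of the 2 values shown sits. Compound 3 `O=C1Nc2ccc(F)cc2/C1=C/c1ccc(-c2cn(-c3ccc(Cl)c(C(F)(F)F)c3)nn2)cc1` carries 4-chloro-3-(trifluoromethyl)phenyl in place of 3-cyanophenyl on an aromatic nitrogen. Going by the values given here, one measured step bears on this change: an at least 2.4-fold higher number from compound 1 to compound 2 (0.38 log units; beyond the scatter), a cyano for fluoro swap on the same aryl group. Compound 3 has no nitrile, and neither has compound 1. A move back towards compound 1 is therefore expected, though a single step supports it only weakly. The expected change is an at least 2.5-fold lower number from compound 2 to compound 3 (0.39 log units; beyond the scatter), a lower number of uncertain size. Compound 3 is estimated at 8000 nM, with an expected range of 2500 nM to 20000 nM.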

Compound 3, half-maximal inhibitory concentration: > 20000 nM
Compound 3 gave a limit, no number; the forecaster's own chance of this, stated with the estimate: 20%; at least 2.5-fold (0.39 log units) between middle value and limit.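

In this assay, 4-chloro-3-(trifluoromethyl)phenyl in place of 3-fluorophenyl on the aromatic nitrogen gives an at least 2.4-fold higher number from compound 1 to compound 3 (0.38 log units; beyond the scatter). Absence of a nitrile is therefore not enough for a measurable value at this position, and only the 3-fluorophenyl of compound 1 gives a number so far. The step from compound 2 to compound 3 cannot be read, as both values are limits: the limit of > 20000 nM in this assay, at which 2 of the 3 values shown sit.

Chloro and trifluoromethyl enter together in compound 3, and their separate shares stay open. Also open, going by these compounds, is whether an amine or a carboxylic acid on this phenyl ring would match or improve on compound 1 at 8190 nM.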